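The source may hold more compounds than are shown below. What is called first, only, known or untested is meant among the compounds shown, and "the series" means these compounds.

In an assay on SK-BR-3 cells for inhibition of Aromatase (Homo sapiens) (on this read-out lower numbers stand for stronger inhibition and higher numbers for weaker inhibition), compound 2 `CC(C)Oc1cc([N+](=O)[O-])ccc1N(C)S(C)(=O)=O` gives 2810 nM, the higher of the two numbers recorded here; compound 1 `CS(=O)(=O)Nc1ccc([N+](=O)[O-])cc1OC1CCCC1` gives 870 nM in this assay, a value beyond the scatter from that of compound 2. Compound 3 `CN(c1ccc([N+](=O)[O-])cc1OC1CCCC1)S(C)(=O)=O` has not been measured. It differs from compound 2 by cyclopentyl in place of isopropyl on an oxygen on an aromatic ring. Among the compounds with values here, no pair of measured compounds shows this change alone, so the size of its step cannot be read from what is recorded. A moderate move toward a lower number is expected, a 1.9-fold lower number from compound 2 to compound 3 (0.27 log units; within the scatter), since compound 1, which carries the cyclopentyl, gives 870 nM. Compound 3 is therefore estimated at 1500 nM in this assay, within 500 nM to 4500 nM.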

Compound 3, half-maximal inhibitory concentration: 440 nM
Estimate against measurement, compound 3: 3.4-fold (0.53 log units) above; measured number outside the range, below it.
By their numbers in this assay, from the lowest: compounds 3 and 1 (each within the scatter of the next); then compound 2.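

In this assay, cyclopentyl in place of isopropyl on an oxygen on an aromatic ring gives a 6.4-fold lower number from compound 2 to compound 3 (0.81 log units; beyond the scatter) and so puts a first measured size on this change, beyond the scatter. Methyl in place of hydrogen on a sulfonamide nitrogen gives a 2.0-fold lower number from compound 1 to compound 3 (0.30 log units; within the scatter) and so does not separate the two cyclopentyl compounds. Nothing recorded here accounts for the size of the cyclopentyl step. Going by these compounds, whether a cyclohexyl ring or a longer chain on that oxygen would lower the number further remains open, as does whether the cyclopentyl step holds when the sulfonamide nitrogen carries hydrogen.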